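The compounds below may be only part of what the source reports. "The series", "measured", "known", "first", "only" and "open" are said of these compounds alone.

Measured so far in a functional assay on Hs-578T cells (Homo sapiens) for inhibition, read by sulforhodamine B assay, with a stated time of 48 h; on this read-out higher numbers stand for weaker inhibition of growth and lower numbers for stronger inhibition of growth:

compound 1 `COc1cc2cc(Oc3ccc(NC(=O)Nc4cccc(C(F)(F)F)c4)cc3)c(C)nc2cc1OC`: 1440 nM
compound 2 `COc1cc2cc(Oc3ccc(NC(=O)Nc4ccc(Cl)c(C(F)(F)F)c4)cc3)c(C)nc2cc1OC`: 720 nM

Among the compounds with values here, compound 2 holds the smaller of the two numbers, with compound 1 as the only comparison; the step of a 2.0-fold lower number from compound 1 to compound 2 (0.30 log units; within the scatter) lies within the scatter, so the two cannot be told apart on this read-out.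

Compound 3 `COc1cc2cc(Oc3ccc(NC(=O)Nc4ccc(Cl)c(Cl)c4)cc3)c(C)nc2cc1OC` differs from compound 2 by chloro in place of trifluoromethyl on an aromatic carbon. Within the data shown here, no measured step exchanges trifluoromethyl for chloro. Among the measured compounds shown here, the only step measured, a 2.0-fold lower number from compound 1 to compound 2 (0.30 log units; within the scatter), adds a chloro to the same ring and stays within the scatter; it says nothing direct about removing the trifluoromethyl. With that as the sole reference, no step beyond the scatter is expected in this assay from compound 2 to compound 3, and the estimate is written around the value of compound 2 with a wide range.

Compound 3 is therefore expected to give about 900 nM, estimated between 350 nM and 2300 nM. This expected step is a 1.3-fold higher number from compound 2 to compound 3 (0.10 log units; within the scatter).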

Compound 3, concentration for 50% growth inhibition: 3530 nM
Compound 3: the middle estimate sits 3.9-fold (0.59 log units) below what was measured; the measured number lies above the stated range.
By their numbers in this assay, from the lowest: compounds 2 and 1 (each within the scatter of the next); then compound 3.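

In this assay, within the data shown here, chloro in place of trifluoromethyl, ortho to a chloro group, is the first single change to pass the scatter, with a 4.9-fold higher number from compound 2 to compound 3 (0.69 log units; beyond the scatter) toward weaker inhibition of growth. The 3,4-dichlorophenyl group also separates from the 3-(trifluoromethyl)phenyl group, with a 2.5-fold higher number from compound 1 to compound 3 (0.39 log units; beyond the scatter) in the same direction, whereas adding chloro to the ring with trifluoromethyl kept stayed within the scatter, so the group held at this position matters more here than the added chloro did. Nothing available explains why trifluoromethyl and chloro differ at this position.

Open, going by these compounds, is how other groups at this position, such as methoxy, nitrile or an amine, would fall relative to trifluoromethyl and chloro. Also open, on these data alone, is whether the same order holds in other cell lines.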